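A few compounds are considered here, and "the series" means these few. Any claim that something is new, unique, unknown or untested is made for them only; others in the source may bear on it.

Measured so far in an assay on liver for inhibition of sterol O-acyltransferase 1 (Rattus norvegicus), using microsomes; a lower number here means a stronger inhibitor, a higher number a weaker inhibitor:
Compound 1 `CC(C)c1cccc(C(C)C)c1NC(=O)NS(=O)(=O)N(C(C)C)C(C)(C)C`, with 140 nM
Compound 2 `CC(C)c1cccc(C(C)C)c1OC(=O)NS(=O)(=O)N1CCCCC1`, with > 100000 nM

Compound 2 stands at a limit of this assay, not at a number, which the limit of > 100000 nM in this assay, at which 1 of the 2 values shown sits, records. Compound 1 gives a measured value in this assay. Compound 3 `CC(C)c1cccc(C(C)C)c1OC(=O)NS(=O)(=O)N(C(C)C)C(C)C` carries diisopropylamino in place of piperidin-1-yl on a sulfonyl sulfur. Among the measured compounds shown here, no step between two measured compounds shows this change. An improvement beyond the scatter is expected from compound 2 to compound 3, though compound 3 is still expected to be weak, and an at least 3.3-fold lower number from compound 2 to compound 3 (0.52 log units; beyond the scatter) gives the expected step. Compound 3 is estimated at 30000 nM, between 3000 nM and 100000 nM.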

Compound 3, half-maximal inhibitory concentration: 15000 nM
For compound 3 the middle estimate is 2.0-fold (0.30 log units) above the measured one; the range from low to high includes it.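

Exchanging piperidin-1-yl for diisopropylamino on a sulfonyl sulfur, with the rest of the structure unchanged, gives an at least 6.6-fold lower number from compound 2 to compound 3 (0.82 log units; beyond the scatter) in this assay; this is the only step shown in which this position alone moves the number. The full size of the step cannot be read, since compound 2 stands at a limit: the limit of > 100000 nM in this assay, at which 1 of the 3 values shown sits.

From the compounds shown here alone, it remains open whether diethylamino at this position would keep the gain, or whether morpholin-4-yl would behave like piperidin-1-yl. Going by these compounds, compound 1 differs from compound 3 in more than one place, so what separates their values also stays open.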